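Urea aryl change: chloro to trifluoromethyl in the series

The source may report more compounds than this note shows. Statements on the series, on what has been measured and on what is new or still open speak of the compounds shown alone.

Compound 1 `O=C(Nc1cccc(-n2cc(-c3ccncc3)c(-c3ccc(Cl)c(O)c3)n2)c1)Nc1ccc(Cl)c(Cl)c1` and compound 2 `O=C(Nc1cccc(-n2cc(-c3ccncc3)c(-c3ccc(Cl)c(O)c3)n2)c1)Nc1cc(C(F)(F)F)cc(C(F)(F)F)c1` share one core and differ only in the urea-bound aryl ring. In a functional assay on MOLT-4 cells (Homo sapiens) for inhibition, read by sulforhodamine B assay, with a stated time of 48 h (on this read-out higher numbers stand for weaker inhibition of growth and lower numbers for stronger inhibition of growth), compound 1 gives > 32500 nM, which is a limit of the assay and not a number, as the limit of > 32500 nM in this assay, at which 1 of the 2 values shown sits, records. Compound 2 in this assay gives 4360 nM. Compound 3 `O=C(Nc1cccc(-n2cc(-c3ccncc3)c(-c3ccc(Cl)c(O)c3)n2)c1)Nc1ccc(Cl)c(C(F)(F)F)c1` is not yet measured and differs from compound 1 by trifluoromethyl in place of chloro on an aromatic carbon. For the measured compounds named here, no step between measured compounds is available for this change. A step of an at least 2.1-fold lower number from compound 1 to compound 3 (0.33 log units; beyond the scatter) toward stronger inhibition is expected. Compound 3 is estimated at 15000 nM, within a range from 5000 nM to 40000 nM.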

Compound 3, concentration for total growth inhibition: 2930 nM
Beside the measured number, compound 3's estimate is 5.1-fold (0.71 log units) above it; the measured number lies below the stated range.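

In this assay, trifluoromethyl in place of chloro on an aromatic carbon, ortho to a chloro group, gives an at least 11-fold lower number from compound 1 to compound 3 (1.04 log units; beyond the scatter). For the compounds shown here, this is the first single-place step, and it shows that the urea-bound aryl ring responds at this position, with the 4-chloro group unchanged. The size of the step is open at one end, because compound 1 sits at a limit of the assay and not a number: the limit of > 32500 nM in this assay, at which 1 of the 3 values shown sits.

Going by these compounds, whether a methyl, bromo or methoxy group on the same carbon would give a similar step remains open.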